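Opening a lactone ring in a terpenoid series

This account rests on a few compounds, and the source may have more. Where it says the series, first, only, none or still open, it means among the compounds named here.

Compound 1 `C=C1CC[C@H]2C(C)(C)CCC[C@]2(C)[C@H]1CCC1=CC(=O)OC1` and compound 2 `C=C1CC[C@H]2C(C)(C)CCC[C@]2(C)[C@H]1C/C=C1\CCOC1=O` share a bicyclic core and differ only in the group carried on a saturated chain carbon bound to a saturated ring carbon. In a functional assay on RAW264.7 cells (Mus musculus) for inhibition, with a stated time of 24 h (on this read-out higher numbers stand for weaker inhibition and lower numbers for stronger inhibition), compound 1 gives 18800 nM, and compound 2 gives 30800 nM. Compound 2 stands highest of the two numbers shown, but its only neighbour is compound 1, and the step of a 1.6-fold higher number from compound 1 to compound 2 (0.21 log units; within the scatter) keeps the two within the usual scatter, so no order between them can be claimed.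

Compound 3 `C=C1CC[C@H]2C(C)(C)CCC[C@]2(C)[C@H]1C/C=C(/C=O)CCO` is not yet measured. It differs from compound 2 as follows: a group of 7 heavy atoms (5 carbon, 2 oxygen; no ring) in place of a group of 7 heavy atoms (5 carbon, 2 oxygen; one five-membered non-aromatic ring with 1 hetero atom), on a saturated chain carbon bound to a saturated ring carbon. Among the measured compounds shown here, the one measured step, from compound 1 to compound 2, swapped one five-membered ring for another and changed little; the move to compound 3 instead opens the ring, so that step is only a loose guide. With nothing showing that this region shifts the number strongly, compound 3 is expected to stay near compound 2, with the step of a 1.2-fold lower number from compound 2 to compound 3 (0.09 log units; within the scatter) estimated to lie within the scatter. Compound 3 is therefore estimated at 25000 nM, with a range from 8000 nM to 80000 nM.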

Compound 3, half-maximal inhibitory concentration: > 50000 nM
Compound 3 ended at the assay's limit; the forecaster's own chance of this, stated with the estimate: 15%; middle value at least 2.0-fold (0.30 log units) from the limit.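

In this assay compound 3 gives > 50000 nM, which is a limit of the assay and not a number. Set against compound 1, the group with no ring gives an at least 2.6-fold higher number from compound 1 to compound 3 (0.42 log units; beyond the scatter), so this position, where exchanging one five-membered ring for another stayed within the scatter, does respond to a change of group, and opening the ring is the only change shown here that goes beyond the scatter. Set against compound 2, the same kind of change gives an at least 1.6-fold higher number from compound 2 to compound 3 (0.21 log units; that floor lies within the scatter), so that pair alone settles no order, and the full size of both steps stays unknown because the reading stops at the assay's limit: the limit of > 50000 nM in this assay, at which 1 of the 3 values shown sits.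

The compounds shown leave open whether the loss of the ring itself goes with the higher number, or the hydroxyl and aldehyde that the open chain carries instead. A ring-free chain ending in a carboxylic acid or an amine, or a five-membered lactam in place of the lactone, would help to separate these two readings.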